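Replacing bromo with hydroxy on an aromatic carbon

A few compounds are considered here, and "the series" means these few. Any claim that something is new, unique, unknown or untested is made for them only; others in the source may bear on it.

In a functional assay on KYSE-450 cells (Homo sapiens) for inhibition, read by MTT assay, with a stated time of 48 h (a lower number here means a stronger inhibitor, a higher number a weaker inhibitor), compound 3 `C/C=C/C(=O)N(Cc1ccc(OC)c(Br)c1)c1cc(OC)c(OC)c(OC)c1` gives 10500 nM as the highest of three numbers, well above compound 1 `COCC(=O)N(Cc1ccc(OC)c(O)c1)c1cc(OC)c(OC)c(OC)c1` at 460 nM and compound 2 `C#CC(=O)N(Cc1ccc(OC)c(O)c1)c1cc(OC)c(OC)c(OC)c1` at 570 nM so far. Compound 4 `C/C=C/C(=O)N(Cc1ccc(OC)c(O)c1)c1cc(OC)c(OC)c(OC)c1` keeps the group on the carbonyl carbon of compound 3 but has hydroxy in place of bromo on an aromatic carbon. It thereby carries the 3-hydroxy-4-methoxyphenyl group found in compound 1 and compound 2. Going by the values given here, no measured step shows this swap directly. Among the compounds with values here, the only measured step (a 1.2-fold higher number from compound 1 to compound 2 (0.09 log units; within the scatter)) changes the group on the carbonyl carbon, so a different group there need not move the number far. Compound 4 is therefore expected to lie near those two. An estimated 18-fold lower number from compound 3 to compound 4 (1.24 log units; beyond the scatter) in this assay would follow, towards a stronger inhibitor. The estimate for compound 4 is 600 nM (expected range 200 nM to 2000 nM).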

Compound 4, half-maximal inhibitory concentration: 67 nM
Compound 4: middle estimate off by 9.0-fold (0.95 log units), on the high side; measured number outside the range, below it.
By their numbers in this assay, from the lowest: compound 4; then compounds 1 and 2 (each within the scatter of the next); then compound 3.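

In this assay this aromatic position proves highly sensitive: hydroxy in place of bromo gives a 160-fold lower number from compound 3 to compound 4 (2.20 log units; beyond the scatter) with the group on the carbonyl carbon unchanged. The group on the carbonyl carbon also counts for more than the earlier step suggested, since with the 3-hydroxy-4-methoxyphenyl group kept, prop-1-en-1-yl gives an 8.5-fold lower number from compound 2 to compound 4 (0.93 log units; beyond the scatter) against ethynyl and a 6.9-fold lower number from compound 1 to compound 4 (0.84 log units; beyond the scatter) against methoxymethyl. Nothing available here explains either change.
The compounds shown leave open whether an amine or a fluoro group at this aromatic position would match hydroxy, and whether a longer chain on the carbonyl carbon would match prop-1-en-1-yl.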